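A Halogen Swap at the Cytotoxicity Ceiling

This account rests on a few compounds, and the source may have more. Where it says the series, first, only, none or still open, it means among the compounds named here.

Compound 1 `COc1cc(OC)c2c(=O)cc(-c3ccc(OCc4cn(-c5ccc(Cl)cc5)nn4)c(OC)c3)oc2c1` is the starting point of this comparison. In an ADME assay on Huh-7 cells (Homo sapiens) for cytotoxicity, read by MTT assay, with a stated time of 72 h (on this read-out higher numbers stand for lower toxicity in this test and lower numbers for higher toxicity in this test), compound 1 gives > 100 ug/mL, which is a limit of the assay rather than a measured number. Compound 2 `COc1cc(O)c(C(=O)/C=C/c2ccc(OCc3cn(-c4ccc(F)cc4Cl)nn3)c(OC)c2)c(OC)c1` likewise gives > 100 ug/mL in this assay, again a limit. Compound 3 `COc1cc(O)c(C(=O)/C=C/c2ccc(OCc3cn(-c4ccccc4Cl)nn3)c(OCc3cn(-c4ccccc4Cl)nn3)c2)c(OC)c1` gives > 100 ug/mL in this assay, once more a limit. All three measured values sit at the limit of > 100 ug/mL in this assay, at which 3 of the 3 values shown sit, so none of these compounds shows a measurable toxicity within the tested range, and nothing separates them from one another.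

Compound 4 `COc1cc(OC)c2c(=O)cc(-c3ccc(OCc4cn(-c5ccc(F)cc5Cl)nn4)c(OC)c3)oc2c1` is not yet measured in this assay. It differs from compound 1 in a single place: 2-chloro-4-fluorophenyl in place of 4-chlorophenyl on an aromatic nitrogen. For the measured compounds named here, no measured pair differs in just one place, so no step size is available from the data, and the three values give no hint of toxicity appearing in this range. Compound 4 is therefore expected to give 100 ug/mL, with a range from 50 ug/mL to 200 ug/mL. The expected step of a number no higher from compound 1 to compound 4 (the limit leaves the size open) is none beyond the usual scatter, and a further limit rather than a number is the most likely outcome.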

Compound 4, half-maximal cytotoxic concentration: > 100 ug/mL
Compound 4: only a limit was reported; the forecaster's own chance of this, stated with the estimate: 85%; the middle value sits exactly at the limit.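

No step can be read from compound 1 to compound 4, because both values stop at a limit of the assay rather than giving numbers: the limit of > 100 ug/mL in this assay, at which 4 of the 4 values shown sit.

From the compounds shown here alone, how far 2-chloro-4-fluorophenyl in place of 4-chlorophenyl alters toxicity, if at all, stays open, as does any difference in toxicity among the four compounds.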